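This account rests on a few compounds, and the source may have more. Where it says the series, first, only, none or still open, it means among the compounds named here.

Compound 1 `O=C(Nc1cc(C(F)(F)F)cc(C(F)(F)F)c1)c1ccccc1O`: 315 nM
Compound 2 `O=C(Nc1cc(C(F)(F)F)cc(C(F)(F)F)c1)c1cccc(Cl)c1O`: 177 nM

In an assay on cells for antagonist activity at P2X purinoceptor 7 (Homo sapiens), read by fluorescence and calcium flux, with a stated time of 30 min (on this read-out lower numbers stand for stronger inhibition and higher numbers for weaker inhibition), compound 2 gives the lower of the two numbers, yet a 1.8-fold lower number from compound 1 to compound 2 (0.25 log units; within the scatter) lies within the scatter, so the two compounds cannot be told apart. Compound 3 `O=C(Nc1cc(C(F)(F)F)cc(C(F)(F)F)c1)c1ccc(Cl)cc1O` differs from compound 2 by 4-chloro-2-hydroxyphenyl in place of 3-chloro-2-hydroxyphenyl on a carbonyl carbon, the same atoms joined differently. Among the compounds with values here, only one measured step bears on this, the addition of chlorine, a 1.8-fold lower number from compound 1 to compound 2 (0.25 log units; within the scatter), and it stayed within the scatter. No step beyond the scatter in this assay is therefore expected. Compound 3 is estimated at 200 nM, between 70 nM and 600 nM, which is expected to mean a 1.1-fold higher number from compound 2 to compound 3 (0.05 log units; within the scatter).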

Compound 3, half-maximal inhibitory concentration: 196 nM
Compound 3: middle estimate off by 1.0-fold (0.01 log units), on the high side, and the stated range covers the measured number.
By their numbers in this assay, from the lowest: compounds 2, 3 and 1 (each within the scatter of the next).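

In this assay, 4-chloro-2-hydroxyphenyl in place of 3-chloro-2-hydroxyphenyl on the carbonyl carbon gives a 1.1-fold higher number from compound 2 to compound 3 (0.04 log units; within the scatter) and so adds a second placement of the chloro group to the first. Chloro in place of hydrogen in this new placement gives a 1.6-fold lower number from compound 1 to compound 3 (0.21 log units; within the scatter) and likewise stays within the scatter, so neither the presence of the chloro group nor its placement separates compound 1, compound 2 and compound 3 on this read-out. No measurement is available that would explain this result. From the compounds shown here alone, whether an amine or a carboxylic acid in place of the chloro group would give a step beyond the scatter remains open.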